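Changing the aryl group of compound 1

The source may report more compounds than this note shows. Statements on the series, on what has been measured and on what is new or still open speak of the compounds shown alone.

Measured in a functional assay on HL-60 cells (Homo sapiens) for inhibition, read by MTT assay, with a stated time of 72 h; a lower number here means a stronger inhibitor, a higher number a weaker inhibitor:
- Compound 1 `CC(=O)Nc1cccc(-c2nc(C)oc2C(=O)N2CCN(c3cccc(Cl)c3)CC2)c1`: 208 nM
- Compound 2 `Cc1nc(-c2ccccc2)c(C(=O)N2CCN(c3cccc(C(F)(F)F)c3)CC2)o1`: 153 nM
- Compound 3 `Cc1nc(-c2cccc(OP(=O)(O)O)c2)c(C(=O)N2CCN(c3cccc(Cl)c3)CC2)o1`: > 1000 nM, a limit of the assay and not a number

Compound 1 stands at 208 nM, within the usual scatter of compound 2 at 153 nM. Compound 3 has no number of its own, only (the limit of > 1000 nM in this assay, at which 1 of the 3 values shown sits).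

Still unmeasured is compound 4 `COc1cc(-c2nc(C)oc2C(=O)N2CCN(c3cccc(Cl)c3)CC2)ccc1O`, which keeps the rest of compound 1 and changes one group: 4-hydroxy-3-methoxyphenyl in place of 3-acetamidophenyl on an aromatic carbon. In words, 4-hydroxy-3-methoxyphenyl stands in place of 3-acetamidophenyl on an aromatic carbon of the five-membered aromatic ring.

Within the data shown here, only one measured step touches this part of the molecule: an at least 4.8-fold higher number from compound 1 to compound 3 (0.68 log units; beyond the scatter). There, a phosphate group takes the place of the acetamido group. That step shows that a change on this phenyl ring can matter in this assay, but its size is only a bound, and compound 4 carries no phosphate group.

The entering and leaving groups both have one six-membered aromatic ring and no net charge. The expected outcome is therefore a 1.1-fold higher number from compound 1 to compound 4 (0.04 log units; within the scatter), with no step beyond the scatter expected. Compound 4 is estimated at 230 nM, with an expected range from 80 nM to 700 nM.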

Compound 4, half-maximal inhibitory concentration: 85.9 nM
For compound 4 the middle estimate is 2.7-fold (0.43 log units) above the measured one; the measured number falls inside the stated range.
By their numbers in this assay, from the lowest: compounds 4, 2 and 1 (each within the scatter of the next, the first and the last beyond it). At a limit, above all of these: compound 3.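

In this assay, this position now has its first step with a real size on both sides, a 2.4-fold lower number from compound 1 to compound 4 (0.38 log units; beyond the scatter), and it points towards a stronger inhibitor, so a change on this phenyl ring can improve the number as well as worsen it. Among these compounds, the only earlier step at this position ended in a limit, which is not a number, for compound 3: the limit of > 1000 nM in this assay, at which 1 of the 4 values shown sits. Nothing measured here gives a reason for the gain seen with 4-hydroxy-3-methoxyphenyl in place of 3-acetamidophenyl.

This single swap removes the acetamido group and brings in both a hydroxy and a methoxy group, so the data cannot say whether one of these alone accounts for the step or whether it takes the two together. A ring carrying only the hydroxy group or only the methoxy group on the same core would separate the two, and a carboxylic acid or an amine on this phenyl ring would show how far the position tolerates other groups.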